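Epimer of compound 2: expected cytotoxicity on gastric cells

The source may report more compounds than this note shows. Statements on the series, on what has been measured and on what is new or still open speak of the compounds shown alone.

The series rests on compound 1 `C=C1C(=O)O[C@@H]2[C@@H]1C[C@H](O)[C@@](O)(CO)CC/C=C(\C)CC/C=C(\C)[C@@H]2O` and compound 2 `C=C1C(=O)O[C@@H]2[C@@H]1C[C@H]1O[C@]1(CO)CC/C=C(\C)CC/C=C(\C)[C@H]2O`, both read in a functional assay on BGC-823 cells (Homo sapiens) for cytotoxicity, read by sulforhodamine B assay; a higher number here means a weaker inhibitor, a lower number a stronger inhibitor. Compound 1 reaches only > 10 ug/mL, which is a limit of the assay and not a number (the limit of > 10 ug/mL in this assay, at which 1 of the 2 values shown sits). Going by the values given here, compound 2 gives 6.3 ug/mL, the only number so far in this assay. Compound 3 `C=C1C(=O)O[C@@H]2[C@@H]1C[C@H]1O[C@]1(CO)CC/C=C(\C)CC/C=C(\C)[C@@H]2O` keeps the whole skeleton of compound 2: the two compounds have the same atoms and bonds and differ only in configuration as drawn: 1 of 7 stereo elements differ; a stereocentre at a saturated ring carbon is drawn R in compound 2 and S in compound 3. Among the compounds with values here, no measured pair shows what a change of configuration alone does here, so the step is expected to sit within the scatter or lean slightly weaker. In this assay the expected step is a 1.2-fold higher number from compound 2 to compound 3 (0.08 log units; within the scatter). Compound 3 is estimated at 7.5 ug/mL, within 2.5 ug/mL to 20 ug/mL.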

Compound 3, half-maximal inhibitory concentration: 5.2 ug/mL
Compound 3: middle estimate off by 1.4-fold (0.16 log units), on the high side, within the range that was stated.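

In this assay, going by these compounds alone, the pair gives the first reading on configuration alone, a 1.2-fold lower number from compound 2 to compound 3 (0.08 log units; within the scatter). Drawing this saturated ring carbon stereocentre as S rather than R therefore gives a reading that cannot be told apart from the original one. The pair isolates this one change: the fact that compounds 2 and 3 differ only in the configuration as drawn

On these data alone, whether the other stereo elements behave in the same way stays open. Also open, as far as these compounds go, is whether an amine on the shared core would move the reading beyond the scatter.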